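This account rests on a few compounds, and the source may have more. Where it says the series, first, only, none or still open, it means among the compounds named here.

Measured so far:
compound 1 `Cc1ccc(/C=N/c2ccc(OCc3ccccc3)cc2)c(O)c1`: > 200000 nM
compound 2 `COc1ccc(/C=N/c2ccc(OCc3ccccc3)cc2)c(O)c1`: > 200000 nM

In a functional assay, with a stated time of 30 min (on this read-out lower numbers stand for stronger inhibition and higher numbers for weaker inhibition), compound 1 gives only a limit, > 200000 nM. In this assay compound 2 likewise gives only a limit, > 200000 nM. Among the compounds with values here, the single measured step, a step that the two limits leave unreadable from compound 1 to compound 2, has no readable size because the limit of > 200000 nM in this assay, at which 2 of the 2 values shown sit, holds both values. Compound 3 `Oc1ccccc1/C=N/c1ccc(OCc2ccccc2)cc1` differs from compound 2 by hydrogen in place of methoxy on an aromatic carbon. Within the data shown here, no measured step bears on this change, so compound 3 is expected to remain at the limit, and a number no higher from compound 2 to compound 3 (the limit leaves the size open) is expected to be unreadable. The estimate for compound 3 is 200000 nM, within 50000 nM to 400000 nM.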

Compound 3, half-maximal inhibitory concentration: > 200000 nM
Compound 3: only a limit was reported; the forecaster's own chance of this, stated with the estimate: 85%; the middle value lies on the limit itself.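

The steps from compound 1 and compound 2 to compound 3 cannot be read, because all three compounds rest on one limit: the limit of > 200000 nM in this assay, at which 3 of the 3 values shown sit.

Going by these compounds, whether methyl, methoxy and hydrogen at this place differ in inhibition at all stays open.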